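The source may hold more compounds than are shown below. What is called first, only, known or untested is meant among the compounds shown, and "the series" means these compounds.

Working notes on a three-compound series read in a functional assay on K562 cells (Homo sapiens) for cytotoxicity, read by XTT assay, with a stated time of 24 h (a lower number here means a stronger inhibitor, a higher number a weaker inhibitor), with a fourth compound still open. Compound 1 `Cc1ccc(NC(=O)c2ccc(Br)cc2OCCCCn2ccnc2)cc1Nc1nccc(-c2cccnc2)n1` gives 66100 nM and stands at the high end of the three numbers, together with compound 3 `Cc1ccc(NC(=O)c2ccc(OCCCCn3ccnc3)cc2)cc1Nc1nccc(-c2cccnc2)n1` at 49900 nM within the scatter of compound 1. Compound 2 `Cc1ccc(NC(=O)c2ccc([N+](=O)[O-])c(OCCCCn3ccnc3)c2)cc1Nc1nccc(-c2cccnc2)n1` gives 25000 nM as a lower number than compound 1, a gap beyond the scatter.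

The step to follow leads from compound 1 to compound 4 `COc1ccc(C(=O)Nc2ccc(C)c(Nc3nccc(-c4cccnc4)n3)c2)c(OCCCCn2ccnc2)c1`, which has methoxy in place of bromo on an aromatic carbon, meta to a 4-(1H-imidazol-1-yl)butoxy group and para to a large group (methoxy in place of bromo on an aromatic carbon).

For the measured compounds named here, no measured pair isolates this change. The expectation therefore rests only on how close the three numbers lie, the widest gap among them being that between compound 1 at 66100 nM and compound 2 at 25000 nM in the same readout. In this assay a small move toward a lower number is expected, with nothing beyond the scatter. The estimated 1.5-fold lower number from compound 1 to compound 4 (0.17 log units; within the scatter) stays within the scatter. For compound 4 the expected value is 45000 nM with an estimated range from 20000 nM to 90000 nM in this readout.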

Compound 4, half-maximal inhibitory concentration: 58900 nM
Compound 4: the middle estimate sits 1.3-fold (0.12 log units) below what was measured; measured number inside the range.
By their numbers in this assay, from the lowest: compounds 2, 3, 4 and 1 (each within the scatter of the next, the first and the last beyond it).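

In this assay the first pair differing in one place gives a 1.1-fold lower number from compound 1 to compound 4 (0.05 log units; within the scatter), so methoxy in place of bromo on this aromatic carbon, meta to a 4-(1H-imidazol-1-yl)butoxy group and para to a large group, leaves the number within the scatter. The readout therefore does not separate these two groups here, even though methoxy brings a hydrogen-bond acceptor that bromo lacks, and this holds for this single position and this single exchange, with no wider pattern to be drawn from it. No evidence at hand bears on why the two compounds read alike.

On these data alone, whether an amine, a carboxylic acid or a longer chain such as butoxy on the same carbon would also stay within the scatter of compound 1 remains open. Also open, as far as these compounds go, is whether the exchange of bromo for methoxy would read the same way with the 4-(1H-imidazol-1-yl)butoxy group placed as in compound 2, or in a readout other than this assay.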